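Trifluoromethyl Gives Way to Nitro

This account rests on a few compounds, and the source may have more. Where it says the series, first, only, none or still open, it means among the compounds named here.

In a functional assay on T29Kt1 cells (Homo sapiens) for cytotoxicity, read by sulforhodamine B assay, with a stated time of 3 days (a higher number here means a weaker inhibitor, a lower number a stronger inhibitor), compound 1 (`OCc1cn(Cc2cccc(Cl)c2)c2ccccc12`) gives 160 nM and compound 2 (`OCc1cn(Cc2cccc(C(F)(F)F)c2)c2ccccc12`) gives 560 nM as the higher of the two numbers. Compound 3 (`O=[N+]([O-])c1cccc(Cn2cc(CO)c3ccccc32)c1`) differs from compound 2 at one place (nitro in place of trifluoromethyl on an aromatic carbon), with nitro in place of trifluoromethyl on an aromatic carbon. Within the data shown here, the only measured step at that carbon is modest and beyond the scatter (a 3.5-fold higher number from compound 1 to compound 2 (0.54 log units; beyond the scatter)). Among the measured compounds shown here, no nitro compound has been measured, so a step no larger than that one, toward a lower number, is expected. The estimated change is a 2.0-fold lower number from compound 2 to compound 3 (0.30 log units; within the scatter) on this basis. Compound 3 is estimated at 280 nM (expected range 90 nM to 850 nM).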

Compound 3, half-maximal inhibitory concentration: 390 nM
Compound 3: middle estimate off by 1.4-fold (0.14 log units), on the low side, within the range that was stated.
By their numbers in this assay, from the lowest: compound 1; then compounds 3 and 2 (each within the scatter of the next).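

In this assay, nitro in place of trifluoromethyl on this aromatic carbon gives a 1.4-fold lower number from compound 2 to compound 3 (0.16 log units; within the scatter), so this change does not separate the two groups. Chloro now stands apart from both, with nitro in its place giving a 2.4-fold higher number from compound 1 to compound 3 (0.39 log units; beyond the scatter), in the same direction as the earlier step with trifluoromethyl. No available evidence accounts for this difference. Going by these compounds, whether an amine or a carboxylic acid at this carbon would fall nearer compound 1 or nearer compound 2 and compound 3 remains open. Also open, on these data alone, is whether bromo or methoxy would match chloro here.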